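The source may report more compounds than this note shows. Statements on the series, on what has been measured and on what is new or still open speak of the compounds shown alone.

Measured in a functional assay on PC-3 cells (Homo sapiens) for inhibition, read by sulforhodamine B assay, with a stated time of 72 h; on this read-out higher numbers stand for weaker inhibition and lower numbers for stronger inhibition:
- compound 1 `CC1CN(C(=O)c2c(N)sc(-c3ccc(Cl)cc3)c2-c2ccc(Cl)cc2)CCN1`: 7210 nM
- compound 2 `CC(C)(C)NC(=O)c1c(N)sc(-c2ccc(Cl)cc2)c1-c1ccc(Cl)cc1`: 15100 nM
- compound 3 `CC(C)CNC(=O)c1c(N)sc(-c2ccc(Cl)cc2)c1-c1ccc(Cl)cc1`: 13200 nM

Compound 3 stands within the scatter of both other compounds: a 1.1-fold lower number from compound 2 to compound 3 (0.06 log units; within the scatter), and a 1.8-fold higher number from compound 1 to compound 3 (0.26 log units; within the scatter). The next structure is compound 4 `CN1CCN(C(=O)c2c(N)sc(-c3ccc(Cl)cc3)c2-c2ccc(Cl)cc2)CC1`, which carries 4-methylpiperazin-1-yl in place of isobutylamino on a carbonyl carbon.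

The nearest evidence comes from compound 1, which holds 3-methylpiperazin-1-yl on that same carbonyl carbon. Two measured steps lead away from it to open-chain amides. One is modest, a 2.1-fold higher number from compound 1 to compound 2 (0.32 log units; beyond the scatter), and the other stays within the scatter, a 1.8-fold higher number from compound 1 to compound 3 (0.26 log units; within the scatter). Exchanging tert-butyl for isobutyl hardly registers, a 1.1-fold lower number from compound 2 to compound 3 (0.06 log units; within the scatter).

Read backwards, these steps suggest a small move toward a lower number in this assay, of about the size of the scatter. The expected step is a 1.7-fold lower number from compound 3 to compound 4 (0.22 log units; within the scatter). Compound 4 is estimated at 8000 nM, with an expected range of 4000 nM to 16000 nM.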

Compound 4, half-maximal inhibitory concentration: 13100 nM
Estimate against measurement, compound 4: 1.6-fold (0.21 log units) below; the range from low to high includes it.
By their numbers in this assay, from the lowest: compounds 1, 4, 3 and 2 (each within the scatter of the next, the first and the last beyond it).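

In this assay the change from an open-chain amide to 4-methylpiperazin-1-yl gives a 1.0-fold lower number from compound 3 to compound 4 (0.00 log units; within the scatter) for isobutylamino and a 1.2-fold lower number from compound 2 to compound 4 (0.06 log units; within the scatter) for (tert-butyl)amino, so neither the ring on this carbonyl carbon nor the loss of the amide hydrogen separates these compounds. The two methylpiperazinyl groups also stay together, with a 1.8-fold higher number from compound 1 to compound 4 (0.26 log units; within the scatter) as their step, so the only gap beyond the scatter remains the modest one of a 2.1-fold higher number from compound 1 to compound 2 (0.32 log units; beyond the scatter) in the earlier pair. Nothing measured here offers an explanation for this flat result.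

From the compounds shown here alone, what remains open is whether any group on this carbonyl carbon can move the number beyond this narrow band. A morpholine ring, an unsubstituted piperazine, a longer alkyl chain or a chain ending in a carboxylic acid would each test that.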